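Benzyl aryl swaps on the shared core, N1303K modulation

This account rests on a few compounds, and the source may have more. Where it says the series, first, only, none or still open, it means among the compounds named here.

Measured so far:
- compound 1 `COc1ccc2[nH]c3c(c2c1)CCNC31CCN(Cc2ccc(Cl)cc2Cl)CC1`: 1800 nM
- compound 2 `COc1ccc2[nH]c3c(c2c1)CCNC31CCN(Cc2ccccc2Cl)CC1`: 2200 nM
- compound 3 `COc1ccc2[nH]c3c(c2c1)CCNC31CCN(Cc2cc(F)cc(F)c2)CC1`: 11100 nM

In an assay on FRT cells for positive allosteric modulation of Cystic fibrosis transmembrane conductance regulator variant N1303K (Homo sapiens), in the presence of a further agent that is not named here (a lower number here means that less compound is needed, a higher number that more compound is needed for the effect), compound 3 stands highest of the three, a 6.2-fold higher number from compound 1 to compound 3 (0.79 log units; beyond the scatter) and a 5.0-fold higher number from compound 2 to compound 3 (0.70 log units; beyond the scatter), while a 1.2-fold higher number from compound 1 to compound 2 (0.09 log units; within the scatter). Compound 4 `COc1ccc2[nH]c3c(c2c1)CCNC31CCN(Cc2cccnc2)CC1` follows from compound 3 by pyridin-3-yl in place of 3,5-difluorophenyl on a saturated chain carbon bound to an amine nitrogen in a ring. Within the data shown here, no measured step exchanges an aryl for a heteroaryl at this place; the two steps that bear on it show only that the aryl group on the saturated chain carbon moves the number by modest amounts. The direction for pyridin-3-yl is therefore open; a change near the scatter or a modest lowering toward the chlorophenyl compounds is expected. Expected step: a 1.4-fold lower number from compound 3 to compound 4 (0.14 log units; within the scatter). Compound 4 is estimated at 8000 nM, range 2500 nM to 25000 nM.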

Compound 4, half-maximal effective concentration: 17000 nM
Compound 4: middle estimate off by 2.1-fold (0.33 log units), on the low side; measured number inside the range.
By their numbers in this assay, from the lowest: compounds 1 and 2 (each within the scatter of the next); then compounds 3 and 4 (each within the scatter of the next).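

In this assay, pyridin-3-yl in place of 3,5-difluorophenyl (a 1.5-fold higher number from compound 3 to compound 4 (0.19 log units; within the scatter)) places the only heteroaryl shown on this saturated chain carbon level with the difluorinated aryl, not with the chlorinated ones. Against the chlorophenyl groups, the same heteroaryl gives larger steps (a 7.7-fold higher number from compound 2 to compound 4 (0.89 log units; beyond the scatter); a 9.4-fold higher number from compound 1 to compound 4 (0.98 log units; beyond the scatter)). Nothing at hand gives a cause for these steps.

On these data alone, whether pyridin-2-yl or pyridin-4-yl would read like pyridin-3-yl remains open. Also open, as far as these compounds go, is whether a chloro group on the pyridine ring would bring the number toward those of compound 1 and compound 2.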